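Cyclohexyl in place of propyl on the amide of compound 1

The source may hold more compounds than are shown below. What is called first, only, known or untested is meant among the compounds shown, and "the series" means these compounds.

Measured compounds:
compound 1 `CCCC(=O)Nc1ccn([C@@H]2CO[C@H](CO)O2)c(=O)n1` — 6600 nM
compound 2 `CCCCCCCCCCCCCCCC(=O)Nc1ccn([C@@H]2CO[C@H](CO)O2)c(=O)n1` — 4 nM
compound 3 `CCCCCCCCCCCCCCCCCCCC(=O)Nc1ccn([C@@H]2CO[C@H](CO)O2)c(=O)n1` — 30 nM

Three amides sharing the same core were tested in a functional assay on A549 cells (Homo sapiens) for cytotoxicity, read by sulforhodamine B assay, with a stated time of 72 h; a higher number here means a weaker inhibitor, a lower number a stronger inhibitor. Compound 1 gives 6600 nM, the highest of the three numbers. Compound 2, which carries a long saturated chain on the carbonyl, gives 4 nM; compound 3, with a still longer chain, gives 30 nM. The single step among these, a 7.5-fold higher number from compound 2 to compound 3 (0.88 log units; beyond the scatter), shows that past a certain length the chain no longer helps. Compound 1 stands far from both of them, with compound 3 its nearest neighbour.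

Compound 4 `O=C(Nc1ccn([C@@H]2CO[C@H](CO)O2)c(=O)n1)C1CCCCC1` differs from compound 1 by cyclohexyl in place of propyl on a carbonyl carbon. Among the compounds with values here, no measured step covers a ring in this position, so the only guide is that larger saturated carbon groups on the carbonyl, as in compound 2 and compound 3, go with much lower numbers than compound 1. Cyclohexyl is larger than propyl but far shorter than either long chain, so a modest move downward is expected rather than a leap. For compound 4 the estimated step is a 3.3-fold lower number from compound 1 to compound 4 (0.52 log units; beyond the scatter). Compound 4 is therefore expected to give about 2000 nM, within a range from 500 nM to 8000 nM.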

Compound 4, half-maximal inhibitory concentration: 7370 nM
Beside the measured number, compound 4's estimate is 3.7-fold (0.57 log units) below it; low and high end bracket the measured number.
By their numbers in this assay, from the lowest: compound 2; then compound 3; then compounds 1 and 4 (each within the scatter of the next).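

In this assay the change at this position gives a 1.1-fold higher number from compound 1 to compound 4 (0.05 log units; within the scatter), so cyclohexyl in place of propyl on a carbonyl carbon leaves compound 4 level with compound 1, even though the entering group has 6 heavy atoms and the leaving group 3. Adding this ring of carbon only therefore does not reproduce the far lower numbers of the long chains: compound 4 gives 7370 nM, whereas compound 2 gives 4 nM and compound 3 gives 30 nM, so among these compounds a larger saturated carbon group on the carbonyl does not by itself go with a lower number, and compound 4 is the exception. Nothing measured here accounts for why the ring makes no visible difference in this assay.

On these data alone, how long an open chain on the carbonyl must be before the number starts to fall remains open, as does whether hexyl, which has the same carbon count as cyclohexyl but no ring, would stay with compound 1 and compound 4 or move toward compound 2. What a phenyl ring on the carbonyl, or a carboxylic acid at the far end of a long chain, would do to the number is also unanswered.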